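A few compounds are considered here, and "the series" means these few. Any claim that something is new, unique, unknown or untested is made for them only; others in the source may bear on it.

Measured so far:
- compound 1 `CC(C)[C@H](C[C@H]1OC(=O)NC1=O)c1ccc(-c2ccc3cccc(F)c3c2)[nH]c1=O` — 35400 nM
- compound 2 `CCC(CC)C(/C=C1\OC(=O)NC1=O)c1ccc(-c2ccc3cccc(F)c3c2)[nH]c1=O` — 33700 nM

In a physicochemical assay for solubility, in phosphate buffer, measured as kinetic solubility (a higher number here means a more soluble compound, a lower number a less soluble compound), compound 1 gives 35400 nM. Compound 2, which carries a different chain and an exocyclic double bond to the ring, gives 33700 nM in this assay. Compound 1 holds the higher of the two numbers, but the gap to compound 2 lies within the scatter, so the two values count as the same for working purposes. Among the measured compounds shown here, no pair of measured compounds differs in only one place, so no measured step exists to lean on.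

Compound 3 `CC(C)[C@@H](c1ccc(-c2ccc3cccc(F)c3c2)[nH]c1=O)[C@H]1OC(=O)NC1=O` remains to be measured in this assay. It differs from compound 1 as follows: 2,4-dioxo-1,3-oxazolidin-5-yl in place of (2,4-dioxo-1,3-oxazolidin-5-yl)methyl on a saturated chain carbon bound to an aromatic carbon and a saturated chain carbon. The ring and all of its donors and acceptors are kept; only the single chain carbon between the ring and the rest of the molecule is lost. With compound 1 and compound 2 sitting at essentially the same value despite larger differences between them, the step is expected to be small: in this assay a 1.2-fold lower number from compound 1 to compound 3 (0.07 log units; within the scatter) is the estimate, with no direction beyond the scatter. Compound 3 is therefore estimated at 30000 nM, in the range 14000 nM to 65000 nM.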

Compound 3, solubility: 31600 nM
For compound 3 the middle estimate is 1.1-fold (0.02 log units) below the measured one, and the stated range covers the measured number.
By their numbers in this assay, from the lowest: compounds 3, 2 and 1 (each within the scatter of the next).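

In this assay, among the compounds shown here, 2,4-dioxo-1,3-oxazolidin-5-yl in place of (2,4-dioxo-1,3-oxazolidin-5-yl)methyl, on a saturated chain carbon bound to an aromatic carbon and a saturated chain carbon, gives a 1.1-fold lower number from compound 1 to compound 3 (0.05 log units; within the scatter), and this is the only step so far that changes a single place. At this position, therefore, the ring attached directly and the ring attached through one chain carbon cannot be told apart in this assay, and the pair gives the series its first reading of a single change rather than a comparison of compounds that differ in more than one place. No supporting measurement bears on this result, so the step stands as an observation without an explanation.

The compounds shown leave open whether a longer chain carrying the same ring, or an amine or a carboxylic acid in place of the ring, would stay at the same level in this assay. They also leave open whether the opposite configuration of the defined stereocentre in 2,4-dioxo-1,3-oxazolidin-5-yl would read any differently.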